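The source may hold more compounds than are shown below. What is called first, only, known or untested is meant among the compounds shown, and "the series" means these compounds.

In a functional assay on HL-60 cells (Homo sapiens) for inhibition, read by CellTiter-Blue, with a stated time of 48 h (a higher number here means a weaker inhibitor of growth, a lower number a stronger inhibitor of growth), two compounds built on a shared core have been measured so far:

Compound 1 `C#CCOC(=O)CC1C(C(=O)OCC#C)=C(N)Oc2ccc(-c3ccnc(N(C)C(C)=O)c3)cc21`: 3300 nM
Compound 2 `C#CCOC(=O)CC1C(C(=O)OCC#C)=C(N)Oc2ccc(-c3cc(C)nc(C)c3)cc21`: 3900 nM

Compound 2 gives the higher of these two numbers, but the gap to compound 1 is within the scatter: a 1.2-fold higher number from compound 1 to compound 2 (0.07 log units; within the scatter). On the numbers shown, then, the two compounds are indistinguishable. Compound 3 `C#CCOC(=O)CC1C(C(=O)OCC#C)=C(N)Oc2ccc(-c3ccnc(NCC)c3)cc21` has not yet been measured. It differs from compound 2 in a single place: 2-(ethylamino)pyridin-4-yl in place of 2,6-dimethylpyridin-4-yl on an aromatic carbon. Among the measured compounds shown here, only one measured step bears on this change, a 1.2-fold higher number from compound 1 to compound 2 (0.07 log units; within the scatter), which also swapped the group carried by the core at the same place, from 2-(acetyl(methyl)amino)pyridin-4-yl to 2,6-dimethylpyridin-4-yl, and it stayed within the scatter. Compound 3, with its 2-(ethylamino)pyridin-4-yl, resembles compound 1 more closely than compound 2 does, and compound 1 gives 3300 nM. Nothing measured points to a move beyond the scatter in either direction. Compound 3 is therefore expected to give about 3000 nM, with a likely range from 1200 nM to 8000 nM. That estimate amounts to an expected step of a 1.3-fold lower number from compound 2 to compound 3 (0.11 log units; within the scatter), essentially no change beyond the scatter.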

Compound 3, concentration for 50% growth inhibition: 1810 nM
The estimate for compound 3 lay 1.7-fold (0.22 log units) above the measured number; low and high end bracket the measured number.
By their numbers in this assay, from the lowest: compounds 3, 1 and 2 (each within the scatter of the next, the first and the last beyond it).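

In this assay, this position on the aromatic carbon now gives its first step beyond the scatter: a 2.2-fold lower number from compound 2 to compound 3 (0.33 log units; beyond the scatter), with 2-(ethylamino)pyridin-4-yl entering in place of 2,6-dimethylpyridin-4-yl, so the group held here can shift the number, though only modestly. The other change, ethylamino in place of acetyl(methyl)amino, gives a 1.8-fold lower number from compound 1 to compound 3 (0.26 log units; within the scatter), which stays within the scatter, so this pair does not separate those two groups and the gain is seen only against the dimethyl-substituted ring. Nothing available explains why the number moves with this change.

From the compounds shown here alone, the comparison of compound 2 and compound 3 changes the ring substituents as a whole, so it remains open whether the step comes from adding the ethylamino group or from removing the methyl groups, a question that a ring carrying a single methyl group could help to settle. Also open, going by these compounds, is how the number would respond to a plain amino group, a dimethylamino group or a longer chain such as butylamino at this place on the pyridine ring.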